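Aryl Swap on a Shared Core: Expecting Compound 4

The compounds below may be only part of what the source reports. "The series", "measured", "known", "first", "only" and "open" are said of these compounds alone.

Measured compounds:
compound 1 `CC#CC(CC(=O)O)c1ccc(OCc2ccc3nc(-c4ccc(C(F)(F)F)cc4)cn3c2)cc1` gives 558 nM in an assay on isolated protein for agonist activity at Free fatty acid receptor 1 (Homo sapiens); on this read-out higher numbers stand for an effect only at larger amounts of compound and lower numbers for an effect already at smaller amounts
compound 2 `CC#CC(CC(=O)O)c1ccc(OCc2ccn3cc(-c4ccc(C(C)C)cc4)nc3c2)cc1` gives 615 nM in this assay
compound 3 `CC#CC(CC(=O)O)c1ccc(OCc2ccc3nc(-c4ccccc4F)cn3c2)cc1` gives 583 nM in this assay

The three numbers lie close together. Compound 2 sits within the usual scatter of both compound 1 and compound 3, so the measurements so far do not separate it from either of them.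

Compound 4 `CC#CC(CC(=O)O)c1ccc(OCc2ccn3cc(-c4ccc(F)cc4F)nc3c2)cc1` has not yet been measured. It differs from compound 2 in one place: 2,4-difluorophenyl in place of 4-isopropylphenyl on an aromatic carbon. Among the measured compounds shown here, the one measured step that bears on this kind of change is an exchange of one aryl group for another at the same kind of position, namely a 1.0-fold higher number from compound 1 to compound 3 (0.02 log units; within the scatter). That exchange, which traded a trifluoromethyl-bearing ring for a fluorine-bearing one, left the read-out unchanged beyond the scatter.

On this basis the step from compound 2 to compound 4 is expected to be small, a 1.0-fold higher number from compound 2 to compound 4 (0.00 log units; within the scatter), with no direction that can be called beyond the scatter. The estimated value for compound 4 is therefore 620 nM, with a range from 300 nM to 1300 nM.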

Compound 4, half-maximal effective concentration: 792 nM
The estimate for compound 4 lay 1.3-fold (0.11 log units) below the measured number; low and high end bracket the measured number.
By their numbers in this assay, from the lowest: compounds 1, 3, 2 and 4 (each within the scatter of the next).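

In this assay, placing 2,4-difluorophenyl in place of 4-isopropylphenyl, on an aromatic carbon of the five-membered aromatic ring, gives a 1.3-fold higher number from compound 2 to compound 4 (0.11 log units; within the scatter). Among the compounds shown here, this is the first measured aryl exchange on the core shared by compound 2 and compound 4, and it shows that a ring carrying two fluorine atoms can replace one carrying an isopropyl group, with one heavy atom fewer, without the number leaving the scatter. The exchange on the core shared by compound 1 and compound 3, a 1.0-fold higher number from compound 1 to compound 3 (0.02 log units; within the scatter), also stays within the scatter, so all the aryl exchanges shown so far agree, and no information at hand accounts for this.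

The compounds shown leave open whether a group of another kind at this place, such as an amine, a carboxylic acid or a longer alkyl chain instead of the substituted phenyl ring, would move the number beyond the scatter. They also leave the two cores uncompared, since no single aryl group appears on both of them.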